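The compounds below may be only part of what the source reports. "The series", "measured", "known", "first", "only" and "open" are said of these compounds alone.

Compound 1 `O=c1nc2ccc(Br)cn2cc1Cc1ccccc1`: > 1000000 nM
Compound 2 `O=c1nc2ccccn2cc1Cc1ccc(Br)cc1`: > 1000000 nM

Of the compounds shown here, two sharing one core have been measured in a functional assay on HepG2 cells (Homo sapiens) for cytotoxicity, read by MTT assay, with a stated time of 24 h; on this read-out higher numbers stand for weaker inhibition and lower numbers for stronger inhibition. Compound 1 returns only a limit of the assay, > 1000000 nM, and not a number. Compound 2 likewise returns only a limit, > 1000000 nM. Compound 2 therefore stands at the limit rather than at any measured point, and all that can be said of it and compound 1 together is that both sit at that limit, as shown by the limit of > 1000000 nM in this assay, at which 2 of the 2 values shown sit. Among the measured compounds shown here, no step between measured compounds exists that could be used to size the effect of a change.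

Compound 3 `O=c1nc2ccccn2cc1Cc1ccccc1` is not yet measured. It differs from compound 2 in one place: hydrogen in place of bromo on an aromatic carbon. For the measured compounds named here, with no measured step to lean on, and with compound 2 at the limit, the expected step in this assay is none beyond the scatter, and the most probable outcome is that compound 3 also stops at the limit. The estimate for compound 3 is 1000000 nM, between 300000 nM and 3000000 nM, which from compound 2 is an expected step of a number no higher from compound 2 to compound 3 (the limit leaves the size open).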

Compound 3, half-maximal inhibitory concentration: > 1000000 nM
Compound 3: only a limit was reported; the forecaster's own chance of this, stated with the estimate: 85%; the middle value lies on the limit itself.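

In this assay compound 3 gives > 1000000 nM, which is a limit and not a number. The steps to compound 3 from compound 1 and from compound 2 therefore cannot be read: the limit of > 1000000 nM in this assay, at which 3 of the 3 values shown sit. The compounds shown leave open whether bromo or hydrogen on the aromatic carbon makes any difference in this assay, since none of them gives a measured number.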